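Enone Mannich base versus amide on a cembranoid core

This account rests on a few compounds, and the source may have more. Where it says the series, first, only, none or still open, it means among the compounds named here.

Measured so far:
compound 1 `CC(C)=CCC[C@]1(C)/C=C/[C@@H](OC(=O)C=C(C)C)[C@](C)(O)/C=C/C(=O)/C(CN(C(C)C)C(C)C)=C\C1` — 650 nM
compound 2 `CC(C)=CCC[C@]1(C)/C=C/[C@@H](OC(=O)C=C(C)C)[C@](C)(O)/C=C/[C@H](O)/C(CO)=C\C1` — > 40000 nM

For the measured compounds named here, in a functional assay on A549 cells (Homo sapiens) for antiproliferative activity, read by MTT assay, with a stated time of 48 h (on this read-out lower numbers stand for stronger inhibition and higher numbers for weaker inhibition), compound 1 gives 650 nM, the only numerical value so far. For compound 2 this assay returns only a limit, > 40000 nM, which is the point at which one of the two values shown sits (the limit of > 40000 nM in this assay, at which 1 of the 2 values shown sits); compound 2 differs from compound 1 in more than one place, so the two values are compared only as they stand.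

Compound 3 `CC(C)=CCC[C@]1(C)/C=C/[C@@H](OC(=O)C=C(C)C)[C@](C)(O)/C=C/C(=O)/C(C(=O)N(C(C)C)C(C)C)=C\C1` is the next member: diisopropylcarbamoyl in place of (diisopropylamino)methyl on a double-bonded ring carbon. Going by the values given here, no single-point step between measured compounds is available to anchor this change. The expectation in this assay is a step toward weaker inhibition, of moderate size, beyond the usual scatter, from compound 1 to compound 3 a 4.6-fold higher number from compound 1 to compound 3 (0.66 log units; beyond the scatter). Compound 3 is therefore estimated at 3000 nM, with a plausible range from 800 nM to 15000 nM.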

Compound 3, half-maximal inhibitory concentration: 13500 nM
Compound 3: the middle estimate sits 4.5-fold (0.65 log units) below what was measured; measured number inside the range.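

In this assay, diisopropylcarbamoyl in place of (diisopropylamino)methyl on the double-bonded ring carbon gives a 21-fold higher number from compound 1 to compound 3 (1.32 log units; beyond the scatter). For the compounds shown here, this is the first step that can be read at a single place, and it shows that the read-out responds strongly to the group on this ring carbon, even though both groups end in the same diisopropyl-substituted nitrogen and the rest of the core is unchanged. No measurement shown accounts for the size of this step.

From the compounds shown here alone, it remains open whether a smaller amine such as dimethylaminomethyl, or a carboxylic acid on this ring carbon, would read closer to compound 1 or to compound 3. Compound 2 gives only a limit, > 40000 nM, and differs from the others in more than one place, so its steps cannot be read.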